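Removing the pentyloxycarbonyl group from compound 2

The source may hold more compounds than are shown below. What is called first, only, known or untested is meant among the compounds shown, and "the series" means these compounds.

In a functional assay for inhibition (on this read-out lower numbers stand for stronger inhibition and higher numbers for weaker inhibition), compound 1 (`CCOC(=O)C(C)(C)Oc1ccc2c(=O)cc(-c3cc(C(C)(C)C)c(O)c(C(C)(C)C)c3)oc2c1`) gives 3000 nM and compound 2 (`CCCCCOC(=O)COc1ccc2c(=O)cc(-c3cc(C(C)(C)C)c(O)c(C(C)(C)C)c3)oc2c1`) gives 5000 nM which places the two level within the scatter. Among the measured compounds shown here, the one measured step (a 1.7-fold higher number from compound 1 to compound 2 (0.22 log units; within the scatter)) exchanged one group on the oxygen for another, so it offers only limited guidance. Compound 3 (`COc1ccc2c(=O)cc(-c3cc(C(C)(C)C)c(O)c(C(C)(C)C)c3)oc2c1`) differs from compound 2 by hydrogen in place of pentyloxycarbonyl on a saturated chain carbon bound to an oxygen on an aromatic ring with hydrogen in place of pentyloxycarbonyl, turning (pentyloxycarbonyl)methoxy into methoxy. For the measured compounds named here, no measured step covers such a removal, so the expected step (a 1.4-fold lower number from compound 2 to compound 3 (0.15 log units; within the scatter)) stays within the scatter, with no clear direction. For compound 3 the estimate is 3500 nM with an expected range from 900 nM to 14000 nM on this read-out.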

Compound 3, half-maximal inhibitory concentration: 1000 nM
Estimate against measurement, compound 3: 3.5-fold (0.54 log units) above; measured number inside the range.
By their numbers in this assay, from the lowest: compound 3; then compounds 1 and 2 (each within the scatter of the next).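

In this assay, among the compounds shown here, shortening the group on this oxygen to methyl gives the first steps beyond the scatter, with a 5.0-fold lower number from compound 2 to compound 3 (0.70 log units; beyond the scatter) and a 3.0-fold lower number from compound 1 to compound 3 (0.48 log units; beyond the scatter) as modest changes. Among the compounds shown, then, neither group carrying an ester gives a lower number than plain methoxy, so the ester chain brings no gain at this position. Nothing available explains why the number drops. On these data alone, whether a longer plain alkyl chain, a free hydroxyl or a carboxylic acid on this carbon or oxygen would behave like methoxy or like the ester-bearing groups remains open.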